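Thiophene for oxazole at the aryl ring of compound 3

The compounds below may be only part of what the source reports. "The series", "measured", "known", "first", "only" and "open" are said of these compounds alone.

The series shares one core and varies the five-membered ring on the chlorinated phenyl. In an assay on isolated protein for inhibition of ubiquitin carboxyl-terminal hydrolase 7 (Homo sapiens), with stated times of 30 min and 2 h (on this read-out lower numbers stand for stronger inhibition and higher numbers for weaker inhibition), compound 1 `Cn1nc2c(=O)n(CC3(O)CCN(Cc4ccc(-c5cnco5)cc4Cl)CC3)cnc2c1-c1ccc(CN)cc1` gives 71.6 nM. Compound 2 `Cn1nc2c(=O)n(CC3(O)CCN(Cc4ccc(-c5ccc[nH]5)cc4Cl)CC3)cnc2c1-c1ccc(CN)cc1` gives 193 nM in this assay, and compound 3 `Cn1nc2c(=O)n(CC3(O)CCN(Cc4ccc(-c5ncco5)cc4Cl)CC3)cnc2c1-c1ccc(CN)cc1` gives 1120 nM. Compound 3 therefore stands at the highest number of the three: the step of a 16-fold higher number from compound 1 to compound 3 (1.19 log units; beyond the scatter) and the step of a 5.8-fold higher number from compound 2 to compound 3 (0.76 log units; beyond the scatter) both point upward, and the step of a 2.7-fold higher number from compound 1 to compound 2 (0.43 log units; beyond the scatter) separates the other two.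

Compound 4 `Cn1nc2c(=O)n(CC3(O)CCN(Cc4ccc(-c5cccs5)cc4Cl)CC3)cnc2c1-c1ccc(CN)cc1` differs from compound 3 only in the change (thiophen-2-yl in place of 1,3-oxazol-2-yl on an aromatic carbon). Going by the values given here, no measured step carries thiophen-2-yl, so the expectation rests on the two steps that lead into compound 3. Both show that replacing 1,3-oxazol-2-yl by another five-membered ring, whether 1,3-oxazol-5-yl or 1H-pyrrol-2-yl, gives a lower number in this assay. Thiophen-2-yl, a five-membered aromatic ring with one hetero atom as under the change above, is expected to behave more like 1H-pyrrol-2-yl than like 1,3-oxazol-2-yl, so a downward step is expected, of the order of the reversed step from compound 2 to compound 3 rather than of the larger step from compound 1.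

Compound 4 is therefore expected to give about 250 nM in this assay, within 80 nM to 800 nM, an estimated step of a 4.5-fold lower number from compound 3 to compound 4 (0.65 log units; beyond the scatter).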

Compound 4, half-maximal inhibitory concentration: 38.6 nM
Compound 4: the middle estimate sits 6.5-fold (0.81 log units) above what was measured; measured number outside the range, below it.
By their numbers in this assay, from the lowest: compounds 4 and 1 (each within the scatter of the next); then compound 2; then compound 3.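

In this assay a five-membered aromatic ring without nitrogen or oxygen is accepted at this position para to a large group, and thiophen-2-yl in place of 1,3-oxazol-2-yl gives a 29-fold lower number from compound 3 to compound 4 (1.46 log units; beyond the scatter) as the largest step in the set. The count of hetero atoms alone does not order these rings: 1H-pyrrol-2-yl and thiophen-2-yl each hold one, yet exchanging them gives a 5.0-fold lower number from compound 2 to compound 4 (0.70 log units; beyond the scatter) on the same read-out. Thiophen-2-yl with one hetero atom and 1,3-oxazol-5-yl with two are not separated, at a 1.9-fold lower number from compound 1 to compound 4 (0.27 log units; within the scatter) in this series.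

Nothing given here bears on the cause of these differences. Still open, on these data alone, is whether thiophen-3-yl, furan-2-yl, a phenyl ring or a pyridine ring at the same position would stay level with compound 4 or fall back towards compound 3, and whether a methyl group or a chloro group on the thiophene ring would move the number in either direction.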